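The compounds below may be only part of what the source reports. "The series", "measured", "known", "first", "only" and "open" are said of these compounds alone.

Measured compounds:
compound 1 `CC(=O)N(Cc1cn(Cc2cccc(F)c2F)nn1)Cc1cn(S(=O)(=O)c2ccc(C)cc2)c2ccccc12` — 9100 nM
compound 2 `CC(=O)N(Cc1cccc(F)c1F)Cc1cn(S(=O)(=O)c2ccc(C)cc2)c2ccccc12` — 17500 nM

In a functional assay on 3T3-L1 cells (Mus musculus) for inhibition, with a stated time of 20 min (a higher number here means a weaker inhibitor, a lower number a stronger inhibitor), compound 1 gives 9100 nM, the lower of the two numbers shown, while compound 2 gives 17500 nM. The gap between them lies within the scatter, so the two are not told apart. Compound 3 `Cc1ccc(S(=O)(=O)N(Cc2cn(Cc3cccc(F)c3F)nn2)Cc2cn(S(=O)(=O)c3ccc(C)cc3)c3ccccc23)cc1` has not yet been measured in this assay. It differs from compound 1 in one place: (4-methylphenyl)sulfonyl in place of acetyl on an amine nitrogen. For the measured compounds named here, no measured pair shows this change, so nothing anchors its direction. The step expected from compound 1 to compound 3 is a 1.1-fold lower number from compound 1 to compound 3 (0.06 log units; within the scatter), none beyond the scatter. Compound 3 is estimated at 8000 nM, with a range from 2500 nM to 25000 nM.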

Compound 3, half-maximal inhibitory concentration: 1700 nM
Compound 3: the middle estimate sits 4.7-fold (0.67 log units) above what was measured, and the stated range ends above it.
By their numbers in this assay, from the lowest: compound 3; then compounds 1 and 2 (each within the scatter of the next).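

Replacing acetyl with (4-methylphenyl)sulfonyl on this amine nitrogen gives, in this assay, a 5.4-fold lower number from compound 1 to compound 3 (0.73 log units; beyond the scatter), the only step beyond the scatter among these compounds. The position therefore accepts a group with an added six-membered aromatic ring, and the number falls rather than rises. Nothing available here explains this step. 

Whether the sulfonyl or the added ring accounts for it stays open: methylsulfonyl or benzoyl on the same nitrogen would separate the two. As far as these compounds go, how a free amine at this position would read also remains unknown.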